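Cyclopentyl for Chlorophenyl: An Expected Cytotoxicity Outcome

A few compounds are considered here, and "the series" means these few. Any claim that something is new, unique, unknown or untested is made for them only; others in the source may bear on it.

Measured compounds:
compound 1, `Cc1cn(C2CCN(Cc3cccc(Oc4cc(C(F)(F)F)cc(C(F)(F)F)c4)c3)CC2)c(=O)[nH]c1=O`, in an ADME assay on MRC5 cells (Homo sapiens) for cytotoxicity, read by fluorescence and resazurin assay, with a stated time of 3 days; a lower number here means a stronger inhibitor, a higher number a weaker inhibitor "not determined" (no result reported)
compound 2, `Cc1cn(C2CCN(Cc3cccc(Oc4cccc(Cl)c4)c3)CC2)c(=O)[nH]c1=O`, in this assay 21000 nM
compound 3, `Cc1cn(C2CCN(Cc3cccc(Oc4ccc(O)cc4)n3)CC2)c(=O)[nH]c1=O`, in this assay "not determined" (no result reported)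

Three compounds share one core, and only compound 2 carries a number in this assay: compound 2 gives 21000 nM. Compound 1 and compound 3 were run without a reported result, so compound 2 stands alone, neither strongest nor weakest, simply the only reference point.

Compound 4, `Cc1cn(C2CCN(Cc3cccc(OC4CCCC4)c3)CC2)c(=O)[nH]c1=O`, has not yet been measured. It differs from compound 2 in a single place: cyclopentyl in place of 3-chlorophenyl on an oxygen on an aromatic ring. Going by the values given here, no step between two measured compounds is available to calibrate this change, so the expectation rests on compound 2 alone.

The account expects no step beyond the usual scatter, with at most a slight drift toward a weaker number, so the estimated change is a 1.4-fold higher number from compound 2 to compound 4 (0.15 log units; within the scatter). Compound 4 is therefore expected to give about 30000 nM in this assay, within a range from 10000 nM to 80000 nM, while a reported limit rather than a number remains a real possibility.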

Compound 4, half-maximal inhibitory concentration: 30300 nM
Beside the measured number, compound 4's estimate is 1.0-fold (0.00 log units) below it, and the stated range covers the measured number.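

In this assay, the change reads as a 1.4-fold higher number from compound 2 to compound 4 (0.16 log units; within the scatter), the first step available at this position. It shows that cyclopentyl can stand in place of 3-chlorophenyl on an oxygen on an aromatic ring without separating the two compounds in this assay, even though a six-membered aromatic ring of carbon only, carrying chlorine, gives way to a five-membered non-aromatic ring of carbon only. No measured evidence is available that bears on this result.

The compounds shown leave open whether a group of a different kind on this oxygen, such as an amine or a carboxylic acid on a longer chain, would give a step beyond the scatter in this assay. They also leave open whether cyclopentyl in place of 3-chlorophenyl would read the same way with any other part of the shared core changed, as this single step is the only one that can be read here.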